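Bromo on the fused core: expected edema inhibition

The source may report more compounds than this note shows. Statements on the series, on what has been measured and on what is new or still open speak of the compounds shown alone.

Measured compounds:
- compound 1 `Clc1ccccc1NCc1nc2ccc(Br)cc2[nH]1`, in a functional assay on the whole organism (strain albino) for inhibition, with Rattus norvegicus as the target, read by paw edema, with a stated time of 60 min, at a dose of 100 mg/kg by the oral route (on this read-out lower numbers stand for less inhibition and higher numbers for more inhibition at the one dose given (going by the name of the read-out)), compound 1 gives 20%
- compound 2 `Clc1cccc(NCc2nc3ccccc3[nH]2)c1`, in this assay compound 2 gives 26.6%
- compound 3 `c1ccc(NCc2nc3ccccc3[nH]2)cc1`, in this assay compound 3 gives 26.6%

Compound 2 stands level with compound 3 at the digits shown, and compound 1 gives a number that differs from compound 2 only within the usual scatter of such measurements. Among the compounds with values here, the one single-point step measured, no change at the digits printed from compound 2 to compound 3 (within the scatter), concerns a hydrogen in place of chloro on an aromatic carbon and shows that this change left the read-out unmoved.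

The step to the unmeasured compound 4 `Clc1cccc(NCc2nc3ccc(Br)cc3[nH]2)c1` is a different one: bromo in place of hydrogen on an aromatic carbon. Within the data shown here, no measured pair isolates this bromo change on the shared core. Compound 1 carries the same bromo and gives a value that sits within the scatter of compound 3, which lacks it, though those two differ in more than one place. With every change seen so far staying inside the scatter, no movement beyond the scatter is expected in this assay for compound 4. Compound 4 is therefore estimated at 23%, in a range from 8% to 38%. This estimate means a step of a number 3.6 percentage points lower from compound 2 to compound 4 (within the scatter).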

Compound 4, a percentage reported as inhibition, in the whole organism at one dose (the size of the read-out at that dose, not a potency): 26.6%
Compound 4: middle estimate off by 3.6 percentage points, on the low side, and the stated range covers the measured number.
By their numbers in this assay, from the lowest: compounds 1, 2, 3 and 4 (each within the scatter of the next).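

In this assay, the new pair gives a direct reading of bromo in place of hydrogen on an aromatic carbon of the shared core, with no change at the digits printed from compound 2 to compound 4 (within the scatter). Within the data shown here, none of the earlier pairs differed by this bromo alone, so this is the first evidence that the change, at this position and with the chloro of compound 2 kept in place, leaves the read-out unmoved. Nothing given here offers a measured explanation for this result.

At this carbon the compounds shown carry only hydrogen and bromo, so the effect of a group such as an amine, a carboxylic acid or a longer chain there remains open. Also open, going by these compounds, is whether bromo would leave the read-out unmoved on compound 3, which carries no chloro.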